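Methoxy in place of benzyloxycarbonyl: an expected non-step

The source may report more compounds than this note shows. Statements on the series, on what has been measured and on what is new or still open speak of the compounds shown alone.

Measured compounds:
compound 1 `Nc1cc(C(=O)OCc2ccccc2)ccc1NC(=O)c1ccc(CNc2nccc(-c3cccnc3)n2)cc1`, > 20000 nM
compound 2 `Nc1ccccc1NC(=O)c1ccc(CNC2=NC[C@H](c3ccccc3)S2)cc1`, "not determined" (no result reported)
compound 3 `Nc1ccccc1NC(=O)c1ccc(CNC2=N[C@@H](Cc3ccccc3)CS2)cc1`, > 20000 nM

All three share an amide-linked aminophenyl core and were tested in an assay on isolated protein for inhibition of protein deacetylase HDAC6 (Homo sapiens), read by fluorescence, with stated times of 3 h and 60 min; a lower number here means a stronger inhibitor, a higher number a weaker inhibitor. For compound 1 the result is only a limit, > 20000 nM, not a measured number. For compound 3 the result is likewise a limit, > 20000 nM. For compound 2 the result is "not determined" (no result reported), so no number is reported. Compound 1 therefore stands nowhere on a scale: two of the three entries, compound 1 among them, sit at the same limit, and the third gives no number at all (the limit of > 20000 nM in this assay, at which 2 of the 3 values shown sit). Among the measured compounds shown here, no pair of measured compounds differs in one place, so no measured step exists.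

For the measured compounds named here, compound 4 `COc1ccc(NC(=O)c2ccc(CNc3nccc(-c4cccnc4)n3)cc2)c(N)c1` is the one compound still to be measured. It differs from compound 1 by a single change (methoxy in place of benzyloxycarbonyl on an aromatic carbon). Going by the values given here, with compound 1 already at the limit and no measured step to lean on, no step beyond the scatter is expected in this assay; the expectation is that the change from compound 1 to compound 4 gives a number no higher from compound 1 to compound 4 (the limit leaves the size open). Compound 4 is thus estimated at 20000 nM, with a range from 5000 nM to 80000 nM, and it is likely that only a limit is reported again.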

Compound 4, half-maximal inhibitory concentration: > 20000 nM
Compound 4 gave a limit, no number (the forecaster's own chance of this, stated with the estimate: 70%); the middle value lies on the limit itself.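

Compound 1 and compound 4 both gave only a limit rather than a number in this assay, so no step can be read between them: the limit of > 20000 nM in this assay, at which 3 of the 4 values shown sit.

The compounds shown leave open how strongly any of them inhibits the enzyme, and whether methoxy in place of benzyloxycarbonyl changes that inhibition at all.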